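Replacing the 4-hydroxyphenyl group of compound 3

The source may report more compounds than this note shows. Statements on the series, on what has been measured and on what is new or still open speak of the compounds shown alone.

Values in a functional assay on A549 cells (Homo sapiens) for inhibition, read by sulforhodamine B assay, with a stated time of 48 h (a lower number here means a stronger inhibitor of growth, a higher number a weaker inhibitor of growth), are as follows
- compound 1 `COc1cc(C=C(C(=O)/C=C/c2ccc(OC)c(OC)c2)C(=O)/C=C/c2ccc(OC)c(OC)c2)ccc1O` gives 530 nM
- compound 2 `COc1ccc(/C=C/C(=O)C(=Cc2ccc(N(C)C)cc2)C(=O)/C=C/c2ccc(OC)c(OC)c2)cc1OC` gives 2620 nM
- compound 3 `COc1ccc(/C=C/C(=O)C(=Cc2ccc(O)cc2)C(=O)/C=C/c2ccc(OC)c(OC)c2)cc1OC` gives 420 nM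

Compound 3 cannot be separated from compound 1, with a 1.3-fold lower number from compound 1 to compound 3 (0.10 log units; within the scatter). It stands clear of compound 2, with a 6.2-fold lower number from compound 2 to compound 3 (0.80 log units; beyond the scatter). The neighbouring step is a 4.9-fold higher number from compound 1 to compound 2 (0.69 log units; beyond the scatter).

Compound 4 `COc1ccc(OC)c(C=C(C(=O)/C=C/c2ccc(OC)c(OC)c2)C(=O)/C=C/c2ccc(OC)c(OC)c2)c1` is unmeasured. Its change is 2,5-dimethoxyphenyl in place of 4-hydroxyphenyl on a double-bonded chain carbon bound to a double-bonded chain carbon. Among the measured compounds shown here, it loses the hydroxy group, as compound 2 does, but no measured compound carries 2,5-dimethoxyphenyl, so the guide is weak. The expected change in this assay is a modest rise, with a 2.0-fold higher number from compound 3 to compound 4 (0.31 log units; beyond the scatter) as the estimate. Compound 4 is expected at 850 nM, with an estimated range from 300 nM to 2600 nM.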

Compound 4, concentration for 50% growth inhibition: 530 nM
For compound 4 the middle estimate is 1.6-fold (0.21 log units) above the measured one; measured number inside the range.
By their numbers in this assay, from the lowest: compounds 3, 1 and 4 (each within the scatter of the next); then compound 2.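

In this assay, 2,5-dimethoxyphenyl on this double-bonded chain carbon cannot be separated from 4-hydroxyphenyl (a 1.3-fold higher number from compound 3 to compound 4 (0.10 log units; within the scatter)) or from 4-hydroxy-3-methoxyphenyl (no change at the digits printed from compound 1 to compound 4 (within the scatter)), so among these compounds the hydroxy group is not needed to hold this level. The gap to 4-(dimethylamino)phenyl (a 4.9-fold lower number from compound 2 to compound 4 (0.69 log units; beyond the scatter)) therefore does not follow from losing the hydroxy group alone. No measurement at hand gives a cause for these steps.

From the compounds shown here alone, it remains open whether the dimethylamino group is unusual at this place. A primary amine or a carboxylic acid on the phenyl ring would test that.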